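From Hexenyl to Hydroxy on the Shared Core

This account rests on a few compounds, and the source may have more. Where it says the series, first, only, none or still open, it means among the compounds named here.

In an ADME assay on L1210/0 cells (Mus musculus) for cytotoxicity, with a stated time of 48 h (a lower number here means a stronger inhibitor, a higher number a weaker inhibitor), compound 1 `O=c1[nH]c(=O)n([C@H]2C[C@H](O)[C@@H](CO)O2)cc1/C=N/O` gives 15500 nM and compound 2 `[N-]=[N+]=NCc1cn([C@H]2C[C@H](O)[C@@H](CO)O2)c(=O)[nH]c1=O` gives 124000 nM, a modest step of an 8.0-fold higher number from compound 1 to compound 2 (0.90 log units; beyond the scatter). Compound 3 `CCCC/C=C\c1cn([C@H]2C[C@H](O)[C@@H](CO)O2)c(=O)[nH]c1=O` gives > 200000 nM, which is a limit and not a number. Its standing therefore rests on (the limit of > 200000 nM in this assay, at which 1 of the 3 values shown sits).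

Compound 4 `O=c1[nH]c(=O)n([C@H]2C[C@H](O)[C@@H](CO)O2)cc1O` has not yet been measured. It carries hydroxy in place of hex-1-en-1-yl on an aromatic carbon, a change counted as hydroxy in place of hex-1-en-1-yl on an aromatic carbon. For the measured compounds named here, no measured step makes this exact exchange, so the nearest guides are the two steps that end at compound 3. One is large, an at least 12-fold higher number from compound 1 to compound 3 (1.11 log units; beyond the scatter). The other, an at least 1.6-fold higher number from compound 2 to compound 3 (0.20 log units; that floor lies within the scatter), has a floor that lies within the scatter.

The closer guide is compound 1, with its 15500 nM and the large step of an at least 12-fold higher number from compound 1 to compound 3 (1.11 log units; beyond the scatter), since there too hex-1-en-1-yl is absent and a group with oxygen stands on that carbon. Compound 2, at 124000 nM, warns that such a replacement need not reach the level of compound 1. A lower number is therefore expected, with an estimated step of an at least 3.3-fold lower number from compound 3 to compound 4 (0.52 log units; beyond the scatter). For compound 4 the estimated value in this assay is 60000 nM, with an expected range of 12000 nM to 200000 nM.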

Compound 4, half-maximal inhibitory concentration: > 200000 nM
Compound 4: a limit, no number; the forecaster's own chance of this, stated with the estimate: 30%; middle value at least 3.3-fold (0.52 log units) from the limit.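

In this assay, hydroxy on this aromatic carbon does not reproduce the result of the group it replaces from compound 1, with an at least 12-fold higher number from compound 1 to compound 4 (1.11 log units; beyond the scatter) and so a clear separation between the two. Against compound 2 the reading is weaker, with an at least 1.6-fold higher number from compound 2 to compound 4 (0.20 log units; that floor lies within the scatter), so that no order between compound 2 and compound 4 can be claimed. Hex-1-en-1-yl and hydroxy, for all the difference in their heavy atoms, both leave the shared core at a limit, the steps between such limits cannot be read, and a lone oxygen on this carbon proves not enough to bring the compound off that limit: the limit of > 200000 nM in this assay, at which 2 of the 4 values shown sit.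

On these data alone, how far apart compound 3 and compound 4 truly lie stays open, since each carries a limit and not a number. Also open, as far as these compounds go, is what in the group of compound 1 sets it apart, and how an amine, a methoxy group or a carboxylic acid on this same carbon would stand against compound 1 and compound 2.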